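The compounds below may be only part of what the source reports. "The series", "measured", "known", "first", "only" and "open" are said of these compounds alone.

Compounds measured:
compound 1, `O=C(O)Cn1nnc(-c2cn(CCCc3cc(Br)c(Br)c(Br)c3)nn2)n1` — 911 nM
compound 2, `NC(=O)c1cn(Cc2cc(Br)c(Br)c(Br)c2)nn1` — 19 nM

In an assay for inhibition of acyl-CoA desaturase 1 (Rattus norvegicus), using microsomes (on this read-out higher numbers stand for weaker inhibition and lower numbers for stronger inhibition), compound 2 stands at the lower of the two numbers shown; compound 1 sits at a markedly higher number, and the gap between them lies beyond the usual scatter. Compound 3, `NC(=O)c1nnn(Cc2cc(Br)c(Br)c(Br)c2)c1N`, differs from compound 2 by amino in place of hydrogen on an aromatic carbon. Among the measured compounds shown here, no measured pair shows a change of this kind, so the size of the step cannot be read off from the data. For compound 3 a step of a 1.6-fold higher number from compound 2 to compound 3 (0.20 log units; within the scatter) is expected, within or only just beyond the scatter. Compound 3 is therefore estimated at 30 nM, in the range 8 nM to 120 nM.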

Compound 3, half-maximal inhibitory concentration: 6 nM
Estimate against measurement, compound 3: 5.0-fold (0.70 log units) above; the whole stated range lies above it.
By their numbers in this assay, from the lowest: compound 3; then compound 2; then compound 1.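

In this assay, amino in place of hydrogen on this aromatic carbon, next to the ring atom that bears a carbamoyl group, gives a 3.2-fold lower number from compound 2 to compound 3 (0.50 log units; beyond the scatter) and so shows that this position takes a substituent with no loss of inhibition. Among the compounds shown here, no earlier pair had changed anything at this place. Nothing among the data given explains the step.

The compounds shown leave open whether a methylamino group, a hydroxyl group or a methyl group on this carbon would give a similar step. They also leave open whether amino here has the same effect on the core of compound 1.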